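The source may hold more compounds than are shown below. What is called first, only, known or untested is meant among the compounds shown, and "the series" means these compounds.

Compound 1 `Cc1occc1-c1nnc2sc(CCCc3ccccc3)nn12` is the weakest of the three compounds measured in an assay for inhibition of histone-lysine N-methyltransferase, H3 lysine-79 specific (Homo sapiens), read by scintillation counting, with stated times of 15 min and 60 min, tested at 50 uM, in the presence of a further agent that is not named here; on this read-out lower numbers stand for a weaker effect and higher numbers for a stronger effect at the one concentration tested: in that assay compound 1 gives 17%. Its nearest neighbour on the numbers is compound 3 `Fc1ccc(-c2nnc3sc(/C=C/c4ccco4)nn23)cc1`, which in this assay gives 44%, and the furthest is compound 2 `C(=C/c1nn2c(-c3ccncc3)nnc2s1)\c1ccco1`, which in this assay gives 67%. Going by the values given here, the one step measured between compounds that differ in a single place runs between those two: a number 23 percentage points lower from compound 2 to compound 3 (beyond the scatter).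

Compound 4 `Cc1occc1-c1nnc2sc(CCc3ccccc3)nn12` differs from compound 1 in one place: phenyl in place of benzyl on a saturated chain carbon, two bonds along the chain from an aromatic carbon. Among the compounds with values here, no measured step describes this change. The step from compound 2 to compound 3 alters the aromatic group on the shared core, not the saturated chain, so it offers no direct guidance on shortening the chain. Within the data shown here, with no comparable step available, the expectation for compound 4 in this assay rests on compound 1 alone and is for no step beyond the scatter, written as a number 3 percentage points higher from compound 1 to compound 4 (within the scatter). Compound 4 is therefore expected to give about 20% in this assay, with an estimated range from 5% to 40%.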

Compound 4, a percentage reported as inhibition, at one concentration (the size of the read-out at that concentration, not a potency): 11%
Estimate against measurement, compound 4: 9 percentage points above; measured number inside the range.
By their numbers in this assay, from the lowest: compounds 4 and 1 (each within the scatter of the next); then compound 3; then compound 2.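

Going by these compounds alone, this is the first measured change on the saturated chain of the shared core, and in this assay the step reads a number 6 percentage points lower from compound 1 to compound 4 (within the scatter). Phenyl in place of benzyl at this carbon, two bonds along the chain from an aromatic carbon, therefore leaves compound 1 and compound 4 indistinguishable on this read-out, so this particular change to the chain gives no measurable separation, whereas the earlier step concerned only the aromatic group on the core. Nothing measured here accounts for this result.

Going by these compounds, whether a longer chain, or an amine or a carboxylic acid in place of the phenyl on this saturated chain carbon, would move the number beyond the scatter remains open. On these data alone, it is also open whether the same exchange of benzyl and phenyl would read the same way on a compound carrying the pyridin-4-yl or 4-fluorophenyl group of compound 2 or compound 3, instead of the aromatic group that compound 1 and compound 4 share.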